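A few compounds are considered here, and "the series" means these few. Any claim that something is new, unique, unknown or untested is made for them only; others in the source may bear on it.

Measured compounds:
compound 1, `CCc1cccc2c1nc(-c1c(F)cccc1F)n2Cc1c(F)cccc1F`, 26.1 uM
compound 2, `Oc1cccc2c1nc(-c1c(F)cccc1F)n2Cc1c(F)cccc1F`, > 100 uM
compound 3, `N=C(NO)c1cccc2c1nc(-c1c(F)cccc1F)n2Cc1c(F)cccc1F`, 23.1 uM

In a toxicity assay on CCRF-CEM cells (Homo sapiens) for cytotoxicity (a higher number here means that more compound is tolerated, a lower number that less compound is tolerated), compound 1 gives 26.1 uM and compound 3 gives 23.1 uM; these two lie within the scatter of each other, as a 1.1-fold lower number from compound 1 to compound 3 (0.05 log units; within the scatter) shows. For compound 2 the assay reports only a limit, > 100 uM, so its true number is not known and it stands apart from the other two at the limit of > 100 uM in this assay, at which 1 of the 3 values shown sits. Both steps that lead to or from compound 2 are therefore at least modest: an at least 3.8-fold higher number from compound 1 to compound 2 (0.58 log units; beyond the scatter), and an at least 4.3-fold lower number from compound 2 to compound 3 (0.63 log units; beyond the scatter).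

Compound 4, `CN(C)C(=O)c1cccc2c1nc(-c1c(F)cccc1F)n2Cc1c(F)cccc1F`, differs from compound 2 in one place: dimethylcarbamoyl in place of hydroxy on an aromatic carbon. Within the data shown here, the hydroxy is thus removed once more, and the only measured steps that bear on this are the two that reach the limit, one going up to it from compound 1 and one coming down from it to compound 3. With the hydroxy exchanged for a different group, the expectation is that the number returns toward the values of compound 1 and compound 3, a downward step beyond the scatter, estimated as an at least 3.3-fold lower number from compound 2 to compound 4 (0.52 log units; beyond the scatter). Compound 4 is accordingly expected to give 30 uM in this assay, within a range from 12 uM to 90 uM.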

Compound 4, half-maximal toxic concentration: 80.1 uM
Compound 4: the middle estimate sits 2.7-fold (0.43 log units) below what was measured; the range from low to high includes it.
By their numbers in this assay, from the lowest: compounds 3 and 1 (each within the scatter of the next); then compound 4. At a limit, above all of these: compound 2.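

In this assay, dimethylcarbamoyl on this aromatic carbon stands apart from both ethyl and the group of compound 3, with a 3.1-fold higher number from compound 1 to compound 4 (0.49 log units; beyond the scatter) and a 3.5-fold higher number from compound 3 to compound 4 (0.54 log units; beyond the scatter). Among these compounds, removing the hydroxy from this position therefore does not by itself return the number to the values of compound 1 and compound 3, as the earlier compounds alone might have suggested. The remaining step, an at least 1.2-fold lower number from compound 2 to compound 4 (0.09 log units; that floor lies within the scatter), cannot be read as a real fall, as it gives only a floor.

As far as these compounds go, how far compound 2 truly lies from the others stays open, as its value is only a limit: the limit of > 100 uM in this assay, at which 1 of the 4 values shown sits. Also open is whether the higher number of compound 4 belongs to dimethylcarbamoyl in particular or would extend to other groups on this carbon, such as an amine, a carboxylic acid or a longer chain.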